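Ring-nitrogen substituent: compound 3 to compound 4

The source may report more compounds than this note shows. Statements on the series, on what has been measured and on what is new or still open speak of the compounds shown alone.

In a functional assay on PC-3 cells (Homo sapiens) for inhibition, read by MTT assay, with a stated time of 72 h (a lower number here means a stronger inhibitor, a higher number a weaker inhibitor), compound 1 `FC(F)(F)c1ccc(CSc2nc(N3CCNCC3)cc(C(F)(F)F)n2)cc1` gives 15900 nM and compound 2 `FC(F)(F)c1ccc(CSc2nc(N3CCN(c4ccccc4)CC3)cc(C(F)(F)F)n2)cc1` gives 42700 nM while compound 3 `CC(C)(C)OC(=O)N1CCN(c2cc(C(F)(F)F)nc(SCc3ccc(C(F)(F)F)cc3)n2)CC1` gives 40600 nM as the starting point here. Compound 3 sits level with compound 2 (a 1.1-fold lower number from compound 2 to compound 3 (0.02 log units; within the scatter)) and apart from compound 1 (a 2.6-fold higher number from compound 1 to compound 3 (0.41 log units; beyond the scatter)). Compound 4 `FC(F)(F)c1ccc(CSc2nc(N3CCN(c4ccccn4)CC3)cc(C(F)(F)F)n2)cc1` carries pyridin-2-yl in place of tert-butoxycarbonyl on an amine nitrogen in a ring. Phenyl in place of hydrogen gave a modest step (a 2.7-fold higher number from compound 1 to compound 2 (0.43 log units; beyond the scatter)) of about the same size as the one with tert-butoxycarbonyl, and exchanging those two substituents changed nothing beyond the scatter. No step beyond the scatter is therefore expected (a 1.1-fold lower number from compound 3 to compound 4 (0.05 log units; within the scatter)). The estimate for compound 4 is 36000 nM within an expected range of 16000 nM to 80000 nM in this assay.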

Compound 4, half-maximal inhibitory concentration: > 50000 nM
Compound 4: only a limit was reported; the forecaster's own chance of this, stated with the estimate: 10%; middle value at least 1.3-fold (0.14 log units) away from the limit.
By their numbers in this assay, from the lowest: compound 1; then compounds 3 and 2 (each within the scatter of the next). At a limit, above all of these: compound 4.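

In this assay compound 4 gives > 50000 nM as a limit of the assay and not a number: the limit of > 50000 nM in this assay, at which 1 of the 4 values shown sits.

An aromatic ring with a hetero atom on this amine nitrogen also gives a higher number than hydrogen (an at least 3.1-fold higher number from compound 1 to compound 4 (0.49 log units; beyond the scatter)), as phenyl and tert-butoxycarbonyl did. Against those two groups the floors lie within the scatter (an at least 1.1-fold higher number from compound 2 to compound 4 (0.06 log units; that floor lies within the scatter); an at least 1.2-fold higher number from compound 3 to compound 4 (0.09 log units; that floor lies within the scatter)), so no order among compounds 2, 3 and 4 can be read.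

Still open, going by these compounds, is how far compound 4 lies beyond its limit. Also open, on these data alone, is whether a methyl group, or a longer chain ending in an amine, on this nitrogen would match the hydrogen of compound 1.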